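Removing the Ethyl Group: From Compound 3 to Compound 4

This account rests on a few compounds, and the source may have more. Where it says the series, first, only, none or still open, it means among the compounds named here.

Measured compounds:
compound 1 `O=C1C(Nc2ccccc2F)=CC(=O)c2c1nc1n2[C@H]2OC[C@@H](O)[C@H]2OC1`: 2000 nM
compound 2 `COc1ccccc1NC1=CC(=O)c2c(nc3n2[C@H]2OC[C@@H](O)[C@H]2OC3)C1=O`: 1670 nM
compound 3 `CCc1ccc(NC2=CC(=O)c3nc4n(c3C2=O)[C@H]2OC[C@@H](O)[C@H]2OC4)cc1`: 1290 nM

All three share one core and differ only in the group on the aromatic ring attached through nitrogen. In a functional assay on MGC-803 cells (Homo sapiens) for inhibition, read by sulforhodamine B assay (on this read-out higher numbers stand for weaker inhibition and lower numbers for stronger inhibition), compound 3 gives the lowest of the three numbers, but compound 2 and compound 1 both lie within the scatter of it, so no order among them can be claimed. Within the data shown here, the one step between neighbours, a 1.2-fold lower number from compound 1 to compound 2 (0.08 log units; within the scatter), was also within the scatter.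

Compound 4 `O=C1C=C(Nc2ccccc2)C(=O)c2c1nc1n2[C@H]2OC[C@@H](O)[C@H]2OC1` differs from compound 3 by hydrogen in place of ethyl on an aromatic carbon. Among the measured compounds shown here, no measured step removes a group from this ring, but the spread among compound 1, compound 2 and compound 3 suggests the ring substituent matters little here. Compound 4 is therefore expected to show a 1.2-fold higher number from compound 3 to compound 4 (0.07 log units; within the scatter), nothing beyond the scatter. The estimated value of compound 4 is 1500 nM, with a range from 700 nM to 3200 nM.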

Compound 4, half-maximal inhibitory concentration: 1730 nM
Compound 4: middle estimate off by 1.2-fold (0.06 log units), on the low side; measured number inside the range.
By their numbers in this assay, from the lowest: compounds 3, 2, 4 and 1 (each within the scatter of the next).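

Replacing ethyl with hydrogen, which turns 4-ethylphenyl into phenyl, gives a 1.3-fold higher number from compound 3 to compound 4 (0.13 log units; within the scatter) in this assay. Among these compounds, this is the first step read at this place on the ring, para to a large group, and it shows that the ethyl group is not needed for a value of this size. Nothing available explains the result. Still open, as far as these compounds go, is whether an amine, a carboxylic acid or a longer chain at this place would move the number beyond the scatter. From the compounds shown here alone, whether the ring itself can be replaced also remains open.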